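Swapping the Aryl Ring: Expected Effect on Cytotoxicity

The compounds below may be only part of what the source reports. "The series", "measured", "known", "first", "only" and "open" are said of these compounds alone.

In a toxicity assay on HepG2 2.2.15 cells (Homo sapiens) for cytotoxicity, read by CCK-8 assay, with a stated time of 8 days (a lower number here means that less compound is tolerated, a higher number that more compound is tolerated), compound 2 `CCOC(=O)c1cn(-c2ccccc2[N+](=O)[O-])nc1CC(C)C` gives 4850 nM, while compound 3 `CC(C)Cc1nn(-c2nccs2)cc1C(=O)NCc1ccc(F)cc1F` gives 83600 nM, the highest of the two numbers measured and a value that lies beyond the scatter from compound 2. Compound 1 `CCOC(=O)c1cn(-c2ccc([N+](=O)[O-])cc2)nc1CC(C)C` gives > 100000 nM, which is a limit of the assay rather than a number. Compound 4 `COc1ccc(CNC(=O)c2cn(-c3nccs3)nc2CC(C)C)cc1` has not yet been measured; it differs from compound 3 by 4-methoxyphenyl in place of 2,4-difluorophenyl on a saturated chain carbon bound to an amide-type nitrogen. For the measured compounds named here, no measured pair shows what such a swap does in this assay, so the change from compound 3 to compound 4 is expected to stay within the usual scatter, with no clear direction. For compound 4 the estimate is 80000 nM, with a range from 30000 nM to 150000 nM. This would mean an expected step of a 1.0-fold lower number from compound 3 to compound 4 (0.02 log units; within the scatter).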

Compound 4, half-maximal cytotoxic concentration: > 100000 nM
Compound 4 gave a limit, no number; the forecaster's own chance of this, stated with the estimate: 30%; at least 1.2-fold (0.09 log units) between middle value and limit.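

this assay now has a measured pair at this position: 4-methoxyphenyl in place of 2,4-difluorophenyl on a saturated chain carbon bound to an amide-type nitrogen gives an at least 1.1-fold higher number from compound 3 to compound 4 (0.07 log units; that floor lies within the scatter). The swap therefore brings no drop in the tolerated concentration. The value of compound 4 is a limit, not a number, so the true size of the step cannot be read: the limit of > 100000 nM in this assay, at which 2 of the 4 values shown sit.

As far as these compounds go, how far compound 4 lies past that limit stays open. So does the effect of an amine or a carboxylic acid at this place.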